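Working notes: 3-methyloxetan-3-yl in place of hydroxymethyl

This account rests on a few compounds, and the source may have more. Where it says the series, first, only, none or still open, it means among the compounds named here.

Measured so far in an ADME assay on microsomes from liver (Homo sapiens) for metabolic stability, read by LC-MS, using NADPH, with a stated time of 30 min, tested at 1 uM; on this read-out higher numbers stand for fast clearance and lower numbers for slow clearance:
compound 1 `CC#Cc1cncc(-c2ccc3c(c2)[C@@]2(COC(N)=N2)c2cc(-c4ccnc(F)c4)ncc2O3)c1`: 40 mL.min-1.g-1
compound 2 `NC1=N[C@@]2(CO1)c1cc(-c3cncc(C#CC4CC4)c3)ccc1Oc1cnc(C3=CCOCC3)cc12`: 80 mL.min-1.g-1
compound 3 `NC1=N[C@@]2(CO1)c1cc(-c3cncc(C#CCO)c3)ccc1Oc1cnc(C3=CCOCC3)cc12`: 84 mL.min-1.g-1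

Compound 3 lies within the scatter of compound 2 and beyond the scatter above compound 1. The next structure is compound 4 `CC1(C#Cc2cncc(-c3ccc4c(c3)[C@@]3(COC(N)=N3)c3cc(C5=CCOCC5)ncc3O4)c2)COC1`, with 3-methyloxetan-3-yl in place of hydroxymethyl on a triple-bonded carbon.

Among the compounds with values here, one measured step bears on this change, because it swaps groups at the same place: a 1.1-fold higher number from compound 2 to compound 3 (0.02 log units; within the scatter). That step, cyclopropyl to hydroxymethyl, stayed within the scatter. Compound 1 differs from compound 3 in more than this one place and offers no direct guide. Within the data shown here, the 3-methyloxetan-3-yl group itself has no measurement yet, so the range stays wide.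

No step beyond the scatter is therefore expected in this assay. The expected step, with a slight lean to a lower number, is a 1.2-fold lower number from compound 3 to compound 4 (0.08 log units; within the scatter). For compound 4 the estimated value is 70 mL.min-1.g-1, with an expected range of 38 mL.min-1.g-1 to 125 mL.min-1.g-1.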

Compound 4, intrinsic clearance in microsomes: 420 mL.min-1.g-1
Compound 4: the middle estimate sits 6.0-fold (0.78 log units) below what was measured; the measured number lies above the stated range.
By their numbers in this assay, from the lowest: compounds 1, 2 and 3 (each within the scatter of the next, the first and the last beyond it); then compound 4.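

In this assay the group on a triple-bonded carbon proves able to move the read-out: cyclopropyl to hydroxymethyl gave only a 1.1-fold higher number from compound 2 to compound 3 (0.02 log units; within the scatter) while 3-methyloxetan-3-yl in place of hydroxymethyl gives a 5.0-fold higher number from compound 3 to compound 4 (0.70 log units; beyond the scatter) and 3-methyloxetan-3-yl in place of cyclopropyl gives a 5.3-fold higher number from compound 2 to compound 4 (0.72 log units; beyond the scatter). Among compounds 2, 3 and 4 the two smaller groups therefore stay together and the 3-methyloxetan-3-yl group alone stands apart, with both of its steps beyond the scatter. Nothing available explains this rise in intrinsic clearance.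

The compounds shown leave open whether the rise belongs to the four-membered ring or to its methyl, a question that oxetan-3-yl without the methyl and an open-chain tert-butyl would address. From the compounds shown here alone, how an amine such as dimethylaminomethyl would read at this place also remains open.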